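The source may hold more compounds than are shown below. What is called first, only, known or untested is meant among the compounds shown, and "the series" means these compounds.

Measured so far in an assay on isolated protein for binding affinity to fibroblast growth factor 2 (Homo sapiens), read by surface plasmon resonance; a lower number here means tighter binding, a higher number weaker binding:
compound 1 `CCN(CC(=O)NC[C@H]1O[C@H](OC)[C@@H](OS(=O)(=O)O)[C@@H](OS(=O)(=O)O)[C@@H]1OS(=O)(=O)O)C(=O)CCCCCCCCCOS(=O)(=O)O` gives 240000 nM;
compound 2 `CO[C@H]1O[C@H](CNC(=O)CN(C(C)=O)C2CCCCCC2)[C@@H](OS(=O)(=O)O)[C@H](OS(=O)(=O)O)[C@@H]1OS(=O)(=O)O` gives 410000 nM;
compound 3 `CO[C@H]1O[C@H](CNC(=O)CN(C(C)=O)c2ccccc2)[C@@H](OS(=O)(=O)O)[C@H](OS(=O)(=O)O)[C@@H]1OS(=O)(=O)O` gives 480000 nM.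

Compound 2 stands second highest of the three numbers; its nearest neighbour is compound 3, its furthest compound 1, and both gaps lie within the scatter. Compound 4 `CCN(CC(=O)NC[C@H]1O[C@H](OC)[C@@H](OS(=O)(=O)O)[C@@H](OS(=O)(=O)O)[C@@H]1OS(=O)(=O)O)C(=O)CCCCC(=O)O` differs from compound 2 in one place: ((4-carboxybutyl)carbonyl)(ethyl)amino in place of acetyl(cycloheptyl)amino on a saturated chain carbon bound to a carbonyl carbon. Among the measured compounds shown here, the only measured step that bears on a swap at this nitrogen is a 1.2-fold higher number from compound 2 to compound 3 (0.07 log units; within the scatter), within the scatter. Compound 1, which also carries an ethyl on this nitrogen and a chain acyl group, and compound 2 differ by no more than the scatter. For the measured compounds named here, no step in this assay has moved beyond the scatter, so for compound 4 a step of a 1.2-fold lower number from compound 2 to compound 4 (0.07 log units; within the scatter) is expected, within the scatter. Compound 4 is therefore estimated at 350000 nM, with a range of 150000 nM to 900000 nM.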

Compound 4, dissociation constant: 480000 nM
Beside the measured number, compound 4's estimate is 1.4-fold (0.14 log units) below it, and the stated range covers the measured number.
By their numbers in this assay, from the lowest: compounds 1, 2, 3 and 4 (each within the scatter of the next).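

In this assay, ((4-carboxybutyl)carbonyl)(ethyl)amino gives a 1.2-fold higher number from compound 2 to compound 4 (0.07 log units; within the scatter) in place of acetyl(cycloheptyl)amino and no change at the digits printed from compound 3 to compound 4 (within the scatter) in place of acetyl(phenyl)amino, so a ring-free acyl chain ending in carboxy also stays within the scatter at this position. Carboxy in place of 5-(sulfooxy)pentyl gives a 2.0-fold higher number from compound 1 to compound 4 (0.30 log units; within the scatter) and is likewise within the scatter, so exchanging that sulfooxy-bearing chain end does not move the number measurably. Nothing available explains this lack of movement.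

Still open, as far as these compounds go, is whether a primary amine or a tetrazole on the acyl chain would give a step beyond the scatter. A much longer chain on this nitrogen is equally untested here.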